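The compounds below may be only part of what the source reports. "The series", "measured", "known", "first", "only" and "open" are said of these compounds alone.

Measured so far:
compound 1 `O=C1N(CCCCCCOc2ccc(Br)cc2)CCN1c1ccncc1`; in a functional assay on cells (Homo sapiens) for cytotoxicity (on this read-out higher numbers stand for lower toxicity in this test and lower numbers for higher toxicity in this test), compound 1 gives > 25000 nM, a limit of the assay.
compound 2 `O=C1N(CCCCCCOc2ccc(Br)cc2)CCN1c1ccnc(Cl)c1`; in this assay compound 2 gives > 25000 nM, again a limit.
compound 3 `O=C1N(CCCCCCOc2ccc(C(F)(F)F)cc2)CCN1c1cccnc1`; in this assay compound 3 gives > 25000 nM, also a limit.

Compound 3 therefore stands at the limit of the assay, and nothing more than that can be read from its value. The same holds across the whole set, since (the limit of > 25000 nM in this assay, at which 3 of the 3 values shown sit); no compound shown gives a number inside the measured range. For the measured compounds named here, the one pair differing in a single place, from compound 1 to compound 2, gives a step that the two limits leave unreadable from compound 1 to compound 2, so even that step carries no readable size.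

The next compound is compound 4 `O=C1N(CCCCCCOc2ccc(Br)cc2)CCN1c1cccnc1`. It differs from compound 3 by bromo in place of trifluoromethyl on an aromatic carbon. Going by the values given here, no measured step bears on this swap: compound 1 and compound 2 carry the bromo group and compound 3 the trifluoromethyl group, and each of them sits at the limit. The expectation is that compound 4 also reaches the limit, with a step that the limit leaves unreadable from compound 3 to compound 4, which means no step beyond the scatter. Compound 4 is thus expected near 30000 nM, within 15000 nM to 100000 nM, most likely reported only as a limit.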

Compound 4, half-maximal cytotoxic concentration: > 25000 nM
Compound 4: a limit, no number; the forecaster's own chance of this, stated with the estimate: 85%; the middle value is on the limit's open side.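

The steps joining compound 4 to compound 1, compound 2 and compound 3 cannot be read, as each runs between two limits in this assay: the limit of > 25000 nM in this assay, at which 4 of the 4 values shown sit.
The compounds shown leave open what size, if any, the swaps among bromo, trifluoromethyl, chloro and the pyridinyl groups have in this assay, and which change would give a value inside the measured range.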